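This account rests on a few compounds, and the source may have more. Where it says the series, first, only, none or still open, it means among the compounds named here.

Measured compounds:
Compound 1, `COc1cc(N)c(Cl)cc1C(=O)CCC1CCN(CCNS(=O)(=O)c2ccc(N)cc2)CC1`, gives 46% in an assay on HEK293 cells for displacement of a labelled ligand from 5-hydroxytryptamine receptor 6 (Homo sapiens), with a stated time of 60 min, tested at 1 uM, in the presence of a further agent that is not named here; a higher number here means a stronger effect of the compound at the concentration tested, a lower number a weaker effect.
Compound 2, `COc1ccc(S(=O)(=O)N2CCC(CCC(=O)c3cc(Cl)c(N)cc3OC)CC2)cc1`, gives "not active" (no number reported) in this assay.
Compound 3, `COc1cc(N)c(Cl)cc1C(=O)CCC1CCN(CCNS(=O)(=O)c2ccc(NC(C)=O)cc2)CC1`, gives 67% in this assay.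

Compound 3 stands highest of the two reported numbers; compound 2 is reported only as not active, without a number. Going by the values given here, the single measured step, a number 21 percentage points higher from compound 1 to compound 3 (beyond the scatter), is a modest rise beyond the scatter and is the only change in this set that touches the ring on the sulfonyl sulfur.

Compound 4, `COc1cc(N)c(Cl)cc1C(=O)CCC1CCN(CCNS(=O)(=O)c2cc(Br)ccc2Br)CC1`, has not yet been measured. It differs from compound 3 in one place: 2,5-dibromophenyl in place of 4-acetamidophenyl on a sulfonyl sulfur. The measured step bears on it only indirectly. It shows that a change at the nitrogen on that ring moves the read-out modestly; the new change removes that nitrogen together with its acetyl and brings in two bromines instead, which is a larger change than the one measured. The direction is therefore open, but since the acetyl raised the number, its loss is more likely to lower it than to raise it.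

Compound 4 is therefore expected to fall below compound 3, by a step of about a number 22 percentage points lower from compound 3 to compound 4 (beyond the scatter), giving an estimated 45% with a range from 15% to 75%.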

Compound 4, a percentage reported as inhibition, at one concentration (the size of the read-out at that concentration, not a potency): 52%
Beside the measured number, compound 4's estimate is 7 percentage points below it; measured number inside the range.
By their numbers in this assay, from the lowest: compounds 1 and 4 (each within the scatter of the next); then compound 3.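

Exchanging 4-acetamidophenyl for 2,5-dibromophenyl on the sulfonyl sulfur gives a number 15 percentage points lower from compound 3 to compound 4 (beyond the scatter), so compound 3 keeps the highest reported number in this assay, yet a ring with two bromines and no nitrogen still gives a measurable read-out. The same position also gives a number 6 percentage points higher from compound 1 to compound 4 (within the scatter), so 2,5-dibromophenyl and 4-aminophenyl are not told apart here, and a nitrogen on this ring is not needed to reach that level, even though the acetyl step on that nitrogen did raise the number. No evidence accompanies these results to explain how the three rings rank.

The compounds shown leave open whether both bromines are needed, since a phenyl ring carrying a single bromine, or one with no further group at all, would separate the contribution of each. They also leave open how a naphthyl group, or a carboxylic acid on the ring, would compare with compound 3 at 67% in this assay, and whether any of these differences would persist as potencies rather than single-concentration read-outs.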